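This account rests on a few compounds, and the source may have more. Where it says the series, first, only, none or still open, it means among the compounds named here.

In an ADME assay on Vero cells (Chlorocebus sabaeus) for cytotoxicity, read by MTT assay, with a stated time of 48 h (on this read-out lower numbers stand for stronger inhibition and higher numbers for weaker inhibition), compound 1 `CC(C)S(=O)(=O)OC1CCC(CN2CCN(c3cc(=O)c4cc(C(F)(F)F)cc([N+](=O)[O-])c4s3)CC2)CC1` gives > 64 ug/mL as a limit of the assay. Compound 2 `O=c1cc(N2CCN(CC3CCC(NS(=O)(=O)c4ccccc4)CC3)CC2)sc2c([N+](=O)[O-])cc(C(F)(F)F)cc12` gives > 64 ug/mL and this too is a limit and not a number. The evidence so far is the limit of > 64 ug/mL in this assay, at which 2 of the 2 values shown sit, and nothing more. Compound 3 `C=CC(=O)OC1CCC(CN2CCN(c3cc(=O)c4cc(C(F)(F)F)cc([N+](=O)[O-])c4s3)CC2)CC1` differs from compound 2 by (vinylcarbonyl)oxy in place of (phenylsulfonyl)amino on a saturated ring carbon with (vinylcarbonyl)oxy in place of (phenylsulfonyl)amino on a saturated ring carbon. Within the data shown here, the only measured step is a step that the two limits leave unreadable from compound 1 to compound 2 and it offers no size to carry over, so no clear shift in either direction is expected in this assay here. The estimated change is a number no higher from compound 2 to compound 3 (the limit leaves the size open) in this assay. Compound 3 is expected near 64 ug/mL with an estimated range of 25 ug/mL to 128 ug/mL in this assay.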

Compound 3, half-maximal inhibitory concentration: > 64 ug/mL
Compound 3: only a limit was reported; the forecaster's own chance of this, stated with the estimate: 70%; the middle value lies on the limit itself.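

In this assay, among these compounds, compound 1, compound 2 and compound 3 each give only a limit, so no step among them can be read. The compounds shown leave open whether their differing groups change this read-out at all.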